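Branching the Alkyl Chain on a Silent Scaffold

A few compounds are considered here, and "the series" means these few. Any claim that something is new, unique, unknown or untested is made for them only; others in the source may bear on it.

Of the compounds shown here, two sharing a common core have been measured in a functional assay with Alpha-1B adrenergic receptor (Homo sapiens) as the target, read by calcium flux; a lower number here means a smaller maximal response, a higher number a larger maximal response. Compound 1, `Cc1n[nH]c(-c2ccccc2NCC2=NCCN2)n1`, gives 0% in this assay. Compound 2, `CCCn1nccc1-c1ccccc1NCC1=NCCN1`, gives 0% in this assay. Compound 2 therefore stands level with compound 1 at the digits reported; the two values lie within the scatter of each other, so neither can be said to differ from the other. Both compounds produce no measurable maximal response.

Compound 3, `CC(C)n1nccc1-c1ccccc1NCC1=NCCN1`, has not yet been measured. It differs from compound 2 in one place: isopropyl in place of propyl on an aromatic nitrogen. The two compounds contain the same atoms, joined differently.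

Among the compounds with values here, no step between measured compounds is available to gauge how a change of this kind moves the maximal response. With both measured compounds already at the floor of this assay, any change could only register as an increase, but nothing in the data points that way. The change is expected to produce a step of no change at the digits printed from compound 2 to compound 3 (within the scatter), which is no step beyond the scatter. Compound 3 is accordingly estimated to give 0% in this assay, within a range from 0% to 10%.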

Compound 3, largest response reached (reported as maximal response), in percent of the reference or control that the assay uses: 0%
Beside the measured number, compound 3's estimate shows no gap at the digits printed; low and high end bracket the measured number.
By their numbers in this assay, from the lowest: compounds 1, 2 and 3 (each within the scatter of the next).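

In this assay, within the data shown here, isopropyl in place of propyl on an aromatic nitrogen gives no change at the digits printed from compound 2 to compound 3 (within the scatter), the only step that can be read at this position. Three carbons joined as a straight chain and three joined as a branch therefore read alike at this place, next to the ring nitrogen and next to the ring atom that bears a large group: compound 3 gives 0% in this assay, so branching the chain here brings no maximal response into view. No measurement at hand speaks to why the two chains read alike.

As far as these compounds go, compound 2 and compound 3 both sit at the bottom of the scale, where a step down cannot show, so it remains open whether any group on this nitrogen can produce a maximal response at all. A longer chain such as hexyl, or a propyl chain ending in an amine or a carboxylic acid, would test this more sharply than another rearrangement of the same three carbons.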